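Halogen swap on the fused core of compound 2

A few compounds are considered here, and "the series" means these few. Any claim that something is new, unique, unknown or untested is made for them only; others in the source may bear on it.

Three compounds have numbers in a functional assay on RAW264.7 cells (Mus musculus) for inhibition, read by microscopy, with a stated time of 4 days, in the presence of a further agent that is not named here; a lower number here means a stronger inhibitor, a higher number a weaker inhibitor. Compound 1 `O=C(Nc1ccc(Cl)cc1F)c1cc(Cl)ccc1O` gives 2120 nM, compound 3 `O=C(Nc1ccc(I)cc1F)c1cc(Cl)ccc1O` gives 1840 nM, and compound 2 `O=c1oc2ccc(Cl)cc2c(=O)n1-c1ccc(I)cc1F` gives 2050 nM; all three lie within the usual scatter of one another, so compound 2 stands with the others rather than apart from them. For the measured compounds named here, the one step recorded so far, a 1.2-fold lower number from compound 1 to compound 3 (0.06 log units; within the scatter), concerns a halogen swap on the ring that carries the amide nitrogen.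

Compound 4 `O=c1oc2ccc(F)cc2c(=O)n1-c1ccc(I)cc1F` is obtained from compound 2 by the change (fluoro in place of chloro on an aromatic carbon). Going by the values given here, no measured pair changes a halogen on the fused core itself, so the only bearing comes from the halogen swap between compound 1 and compound 3, which stayed within the scatter. On that basis no step beyond the scatter is expected in this assay in either direction, and the estimate for compound 4 is therefore 2300 nM, with a range from 1000 nM to 5300 nM, meaning an expected step of a 1.1-fold higher number from compound 2 to compound 4 (0.05 log units; within the scatter).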

Compound 4, half-maximal inhibitory concentration: 2050 nM
Beside the measured number, compound 4's estimate is 1.1-fold (0.05 log units) above it; low and high end bracket the measured number.
By their numbers in this assay, from the lowest: compounds 3, 2, 4 and 1 (each within the scatter of the next).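

In this assay, the pair on the fused core reads no change at the digits printed from compound 2 to compound 4 (within the scatter), so at this aromatic carbon the data do not separate fluoro from chloro. The earlier step, a 1.2-fold lower number from compound 1 to compound 3 (0.06 log units; within the scatter), concerned only a halogen swap on the ring carrying the amide nitrogen; a halogen swap on the fused core now also stays within the scatter, and neither of these two pairs goes against that reading. Nothing measured here bears on why the two numbers coincide.

The compounds shown leave open what an amine, a carboxylic acid or a longer chain on this same aromatic carbon would give. They also leave open whether any group other than a halogen here would produce a step beyond the scatter.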